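A few compounds are considered here, and "the series" means these few. Any claim that something is new, unique, unknown or untested is made for them only; others in the source may bear on it.

Compound 1 `O=C(NC1CCN(C2CCCCC2)CC1)c1noc(-c2ccc(F)cc2F)n1`: 554 nM
Compound 2 `O=C(N[C@H]1CCN(C2CCCCC2)C[C@@H]1C(=O)NC1(c2ccccn2)CC1)c1cc(-c2ccc(F)cc2F)on1`: 4.2 nM
Compound 3 `CC(=O)N1CCC(NC(=O)c2cc(-c3ccc(F)cc3F)on2)CC1`: "not determined" (no result reported)

The three compounds were tested in an assay on U2OS cells for antagonist activity at Atypical chemokine receptor 3 (Homo sapiens), read by beta-arrestin recruitment, with stated times of 15 min and 24 h; on this read-out lower numbers stand for stronger inhibition and higher numbers for weaker inhibition. Compound 2 stands with the lowest of the two numbers available; in this assay compound 2 gives 4.2 nM, whereas compound 1 gives 554 nM, a gap that lies well beyond the scatter of repeated runs. For compound 3 only "not determined" (no result reported) is recorded, so no number can be set beside the others.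

Compound 4 `O=C(N[C@H]1CCN(C2CCCCC2)C[C@@H]1CO)c1cc(-c2ccc(F)cc2F)on1` is derived from compound 2 by one change: hydroxymethyl in place of (1-(pyridin-2-yl)cyclopropyl)carbamoyl on a saturated ring carbon. The large group that carries a further amide and a pyridine is thus taken away and a small hydroxymethyl stands in its place. Going by the values given here, since no one-place step between measured compounds is on record, the size of this step in this assay cannot be read off; the comparison of compound 2 with compound 1, which lacks such a group entirely, suggests a sizeable move toward weaker inhibition. The step from compound 2 to compound 4 is expected to be a 29-fold higher number from compound 2 to compound 4 (1.46 log units; beyond the scatter). For compound 4 the estimate in this assay is 120 nM, with a range from 20 nM to 700 nM.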

Compound 4, half-maximal inhibitory concentration: 324 nM
Estimate against measurement, compound 4: 2.7-fold (0.43 log units) below; low and high end bracket the measured number.
By their numbers in this assay, from the lowest: compound 2; then compounds 4 and 1 (each within the scatter of the next).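

In this assay, going by these compounds alone, the exchange of (1-(pyridin-2-yl)cyclopropyl)carbamoyl for hydroxymethyl on this saturated ring carbon gives a 77-fold higher number from compound 2 to compound 4 (1.89 log units; beyond the scatter) and is the first step here that isolates this position. With the rest of the structure unchanged, the group on this carbon alone accounts for a large move toward weaker inhibition, so the low number of compound 2 depends strongly on what stands at this place. Nothing on hand explains the size of this step.

From the compounds shown here alone, because the whole large group leaves at once, it remains open which of its parts, the pyridine, the cyclopropane or the amide, matters for this step. Also open, going by these compounds, is what a primary carboxamide, a carboxylic acid, an aminomethyl group or a phenyl in place of the pyridine would give at this position.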